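Swapping 4-bromophenyl for 2,4-dichlorophenyl on a weakly cytotoxic series

This account rests on a few compounds, and the source may have more. Where it says the series, first, only, none or still open, it means among the compounds named here.

Among the compounds with values here, in a functional assay on A549 cells (Homo sapiens) for cytotoxicity, read by MTT assay, with a stated time of 72 h (on this read-out higher numbers stand for weaker inhibition and lower numbers for stronger inhibition), compound 3 `COc1ccc(/C=C2\CCC/C(=C\c3ccc(Br)cc3)C2=O)cc1OC` gives 16000 nM, the only actual number among the three compounds measured so far. Compound 1 `COc1cccc(/C=C2\CCC/C(=C\c3cccc(Cl)c3Cl)C2=O)c1OC` gives > 20000 nM in this assay, which is a limit and not a number. Compound 2 `COc1cccc(/C=C2\CCC/C(=C\c3ccc(O)c(Cl)c3)C2=O)c1OC` gives > 20000 nM in this assay, which is likewise a limit. The picture so far comes down to the limit of > 20000 nM in this assay, at which 2 of the 3 values shown sit.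

Compound 4 `COc1ccc(/C=C2\CCC/C(=C\c3ccc(Cl)cc3Cl)C2=O)cc1OC` has not yet been measured. It differs from compound 3 in one place, with 2,4-dichlorophenyl in place of 4-bromophenyl on a double-bonded chain carbon bound to a double-bonded ring carbon.

Within the data shown here, only one measured step exists to draw on, and it concerns a different swap at that kind of place: a step that the two limits leave unreadable from compound 1 to compound 2. Among the measured compounds shown here, it therefore offers no size to carry over, and no measured step speaks for a direction. The expectation rests on compound 3 at 16000 nM alone. What is expected in this assay is a 1.1-fold lower number from compound 3 to compound 4 (0.03 log units; within the scatter), which means no step beyond the usual scatter, although a reading at the limit would be no surprise. For compound 4 the estimated value is 15000 nM, with an expected range from 6000 nM to 20000 nM.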

Compound 4, half-maximal inhibitory concentration: > 20000 nM
Compound 4: no number, only a limit; the forecaster's own chance of this, stated with the estimate: 40%; at least 1.3-fold (0.12 log units) between middle value and limit.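

Compound 4 gives only a limit in this assay, so 2,4-dichlorophenyl on a double-bonded chain carbon bound to a double-bonded ring carbon brings no actual number into view. Within the data shown here, the swap from 4-bromophenyl reads as an at least 1.2-fold higher number from compound 3 to compound 4 (0.09 log units; that floor lies within the scatter), the first step with a readable direction, yet the true size of the change remains unknown and could be small or large. Among these compounds, compound 3 therefore remains the only compound with an actual number, and the rest of the series is defined by a single ceiling: the limit of > 20000 nM in this assay, at which 3 of the 4 values shown sit.

The step from compound 1 to compound 2 cannot be read, which leaves no second size to set beside this floor and no way to tell how much the substituents on this aryl ring matter. Also open, from the compounds shown here alone, is whether an amine or a carboxylic acid on the phenyl ring at this place, in place of the halogens, would give a number clearly lower than that of compound 3 or would stay at the limit.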